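The compounds below may be only part of what the source reports. "The series", "measured", "known", "first", "only" and "open" are said of these compounds alone.

In a functional assay on MCF7 cells (Homo sapiens) for inhibition, read by MTT assay, with a stated time of 72 h (a higher number here means a weaker inhibitor, a lower number a stronger inhibitor), compound 1 (`COc1cc2c(Oc3ccc(NC(=O)c4nn(-c5ccccc5C)cc(C)c4=O)cc3F)ccnc2cc1OCCCC(=O)NO`) gives 2600 nM and compound 2 (`COc1cc2c(Oc3ccc(NC(=O)c4nn(-c5ccccc5F)cc(C)c4=O)cc3F)ccnc2cc1OCCCC(=O)NO`) gives 2100 nM. These two compounds differ by a fluoro in place of a methyl on an aromatic carbon, and that swap gives a 1.2-fold lower number from compound 1 to compound 2 (0.09 log units; within the scatter). On these numbers, compound 2 therefore stands level with compound 1, and neither can be called the stronger inhibitor.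

Compound 3 (`COc1cc2c(Oc3ccc(NC(=O)c4nn(-c5ccccc5F)cc(C)c4=O)cc3F)ccnc2cc1OCCCCCC(=O)NO`) keeps all of compound 2 except the chain that ends in the hydroxamic acid group: 2-(hydroxycarbamoyl)ethyl in place of hydroxycarbamoyl on a saturated chain carbon, three bonds along the chain from an oxygen on an aromatic ring. Read one bond further out, 3-(hydroxycarbamoyl)propyl becomes 5-(hydroxycarbamoyl)pentyl, so the chain grows longer and its end group stays the same.

Among the compounds with values here, the one measured step changes a different place and leaves this chain untouched, so it gives only a weak guide. Within the data shown here, no measured pair shows what chain length does in this assay. A small step is the cautious expectation, and its direction remains uncertain. The estimated change is a 1.4-fold lower number from compound 2 to compound 3 (0.15 log units; within the scatter). For compound 3, the expected value is 1500 nM, with an estimated range from 500 nM to 4500 nM.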

Compound 3, half-maximal inhibitory concentration: 2320 nM
Estimate against measurement, compound 3: 1.5-fold (0.19 log units) below; the range from low to high includes it.
By their numbers in this assay, from the lowest: compounds 2, 3 and 1 (each within the scatter of the next).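

Within the data shown here, this is the first measured step at the chain itself: in this assay, 5-(hydroxycarbamoyl)pentyl in place of 3-(hydroxycarbamoyl)propyl gives a 1.1-fold higher number from compound 2 to compound 3 (0.04 log units; within the scatter). With the hydroxycarbamoyl end group kept, this lengthening therefore produces no difference that can be told apart from the ordinary spread of repeated measurements, so this place on the chain accepts the longer form with no readable gain or loss in these cells. No supporting measurement is available to explain this result.

On these data alone, two chain lengths on one background cannot define a trend, so it remains open whether a shorter chain such as (hydroxycarbamoyl)methyl, or a chain longer than 5-(hydroxycarbamoyl)pentyl, would also leave the number level, and whether the same lengthening would behave alike with the methyl of compound 1 in place of the fluoro. As far as these compounds go, the role of the end group is also open, since a carboxylic acid or an amine at the end of the chain in place of hydroxycarbamoyl would show whether that group matters in this assay.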